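Moving a Hydroxyl Group on One Outer Ring

The source may report more compounds than this note shows. Statements on the series, on what has been measured and on what is new or still open speak of the compounds shown alone.

Three compounds that share a core built around a six-membered aromatic ring with 1 nitrogen were tested in a functional assay on T47D cells (Homo sapiens) for inhibition; a higher number here means a weaker inhibitor, a lower number a stronger inhibitor. Compound 1, `Oc1cccc(-c2cc(-c3cccc(C(F)(F)F)c3)cc(-c3ccccc3O)n2)c1`, gives 6340 nM. Compound 2, `Oc1ccc(-c2cc(-c3cccc(C(F)(F)F)c3)cc(-c3ccccc3O)n2)cc1`, reaches only a limit of the assay, > 50000 nM. The change from compound 1 to compound 2 is 4-hydroxyphenyl in place of 3-hydroxyphenyl on an aromatic carbon, and the step is an at least 7.8-fold higher number from compound 1 to compound 2 (0.89 log units; beyond the scatter); its full size stays hidden by the limit of > 50000 nM in this assay, at which 1 of the 3 values shown sits. Compound 3, `Oc1cccc(-c2cc(-c3ccccc3OC(F)(F)F)cc(-c3ccccc3O)n2)c1`, gives 2680 nM, and the difference between its core and that of compound 1 is not broken down here. Compound 4, `Oc1ccc(-c2cc(-c3ccccc3OC(F)(F)F)cc(-c3ccccc3O)n2)cc1`, has not yet been measured; it differs from compound 3 by 4-hydroxyphenyl in place of 3-hydroxyphenyl on an aromatic carbon. For the measured compounds named here, this is the same kind of change as the one from compound 1 to compound 2, though the surroundings are not identical: in the first pair the changed ring sits meta to a 3-(trifluoromethyl)phenyl group, whereas in compound 3 it sits meta to a large group. Resting on the measured step from compound 1 to compound 2, an at least 7.8-fold higher number from compound 1 to compound 2 (0.89 log units; beyond the scatter), a weakening of comparable size is expected from compound 3 to compound 4, a 9.3-fold higher number from compound 3 to compound 4 (0.97 log units; beyond the scatter). Compound 4 is therefore estimated to give 25000 nM in this assay, most likely between 8000 nM and 80000 nM, with a fair chance that only a limit is reported.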

Compound 4, half-maximal inhibitory concentration: 2050 nM
Estimate against measurement, compound 4: 12-fold (1.09 log units) above; measured number outside the range, below it.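

In this assay, the same swap of 3-hydroxyphenyl for 4-hydroxyphenyl on the core of compound 3 gives a 1.3-fold lower number from compound 3 to compound 4 (0.12 log units; within the scatter), so the clear loss seen on the core of compound 1 does not carry over to this second core, and the two outcomes really do differ: the same change on two cores in this assay, an at least 7.8-fold higher number (0.89 log units; beyond the scatter) from compound 1 to compound 2 and a 1.3-fold lower number (0.12 log units; within the scatter) from compound 3 to compound 4, at least 10-fold (1.01 log units) apart, beyond the scatter of two such steps Compound 2 is a limit and not a number, so the step leading to it has no known full size: the limit of > 50000 nM in this assay, at which 1 of the 4 values shown sits. This shows that the outcome of moving the hydroxyl in this series depends on the rest of the molecule, so a step measured on one core cannot simply be transferred to another, but two pairs cannot show which feature of the cores is responsible, or why.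

On these data alone, all four compounds keep a 2-hydroxyphenyl group and a hydroxyl on the other outer ring, so it remains open how the series would respond if that second hydroxyl were replaced by an amine or a carboxylic acid. As far as these compounds go, it also remains open how the swap would behave on further cores, for example with a simple methyl group on the third outer ring in place of the groups carrying fluorine.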